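The compounds below may be only part of what the source reports. "The series", "measured", "known", "first", "only" and "open" are said of these compounds alone.

Measured so far in a functional assay on ZR-75-1 cells (Homo sapiens) for inhibition, read by sulforhodamine B assay; on this read-out higher numbers stand for weaker inhibition of growth and lower numbers for stronger inhibition of growth
- Compound 1 `Cc1ccc2[nH]c(-c3ccc(-c4ccc(-c5ccc(N(C)C)cc5)cc4)cc3)nc2c1` gives 7200 nM
- Compound 2 `COc1ccc(-c2ccc(-c3ccc(-c4nc5cc(C)ccc5[nH]4)cc3)cc2)cc1OC` gives 3100 nM
- Compound 3 `Fc1ccc(-c2ccc(-c3ccc(-c4nc5ccccc5[nH]4)cc3)cc2)cc1` gives 100000 nM

Compound 3 at 100000 nM has the highest number of the three and so is the weakest growth inhibitor among them. The change to compound 4 `Cc1ccc2[nH]c(-c3ccc(-c4ccc(-c5ccc(F)cc5)cc4)cc3)nc2c1` is methyl in place of hydrogen on an aromatic carbon and nothing else, so methyl in place of hydrogen on an aromatic carbon is the whole difference. Among the measured compounds shown here, no measured step isolates this methyl. For the measured compounds named here, the one step available is a 2.3-fold lower number from compound 1 to compound 2 (0.37 log units; beyond the scatter) and it concerns a different group, with the methyl present on both sides. Compound 1 at 7200 nM and compound 2 at 3100 nM both carry the methyl and both sit well under compound 3, but they also differ from it in another group, so that gap cannot be assigned to the methyl alone. Only part of it is expected to carry over. In this assay the expected step is a 6.7-fold lower number from compound 3 to compound 4 (0.82 log units; beyond the scatter) as an estimate, toward a lower number and with wide uncertainty. For compound 4 the estimated value is 15000 nM with an expected range from 3500 nM to 80000 nM as the likely span.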

Compound 4, concentration for 50% growth inhibition: 35000 nM
The estimate for compound 4 lay 2.3-fold (0.37 log units) below the measured number; measured number inside the range.
By their numbers in this assay, from the lowest: compound 2; then compound 1; then compound 4; then compound 3.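

In this assay the methyl on the aromatic carbon of the fused system of two rings now has a step of its own, a 2.9-fold lower number from compound 3 to compound 4 (0.46 log units; beyond the scatter), so this change alone gives a modest gain in growth inhibition. With the methyl present on both sides, the group on the other aromatic carbon also counts: the step is large for 4-fluorophenyl in place of 3,4-dimethoxyphenyl, an 11-fold higher number from compound 2 to compound 4 (1.05 log units; beyond the scatter), and modest for fluoro in place of dimethylamino, a 4.9-fold higher number from compound 1 to compound 4 (0.69 log units; beyond the scatter), so the methyl does not bring compound 4 level with either partner. No measurement is available that explains these steps.

On these data alone, whether an ethyl, a chloro or a carboxylic acid at this carbon would do better or worse than methyl remains open. So does whether the methyl step would keep its size alongside the 3,4-dimethoxyphenyl group.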